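The source may report more compounds than this note shows. Statements on the series, on what has been measured and on what is new or still open speak of the compounds shown alone.

Compound 1 `O=C(NO)[C@H]1CC[C@]2(CC1)OO[C@]1(O2)C2CC3CC(C2)CC1C3` carries a hydroxycarbamoyl on the shared core. In a functional assay on A549 cells (Homo sapiens) for cytotoxicity, read by MTT assay, with a stated time of 48 h (on this read-out higher numbers stand for weaker inhibition and lower numbers for stronger inhibition), compound 1 gives > 50000 nM, which is a limit of the assay and not a number. Compound 2 `O=C(O)[C@H]1CC[C@]2(CC1)OO[C@]1(O2)C2CC3CC(C2)CC1C3` differs from it by hydroxy in place of hydroxyamino on a carbonyl carbon. In this assay compound 2 gives > 100000 nM, again a limit. The step that the two limits leave unreadable from compound 1 to compound 2 stays unsized, since both readings sit at limits (the limit of > 100000 nM in this assay, at which 1 of the 3 values shown sits, (the limit of > 50000 nM in this assay, at which 2 of the 3 values shown sit)). Compound 3 `O=C(NO)[C@H]1CC[C@@]2(CC1)OC[C@]1(OO2)C2CC3CC(C2)CC1C3` has another core; the difference between the two cores is not broken down here. In this assay compound 3 gives > 50000 nM, a limit. Compound 4 `O=C(O)[C@H]1CC[C@@]2(CC1)OC[C@]1(OO2)C2CC3CC(C2)CC1C3` is unmeasured and differs from compound 3 by hydroxy in place of hydroxyamino on a carbonyl carbon, the same change at the same place as between compound 1 and compound 2. Compound 4 is expected to show a step that the limit leaves unreadable from compound 3 to compound 4 in this assay, resting on the unreadable step that the two limits leave unreadable from compound 1 to compound 2. Compound 4 is estimated at 150000 nM, most likely reported as a limit only.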

Compound 4, half-maximal inhibitory concentration: > 100000 nM
Compound 4 ended at the assay's limit; the forecaster's own chance of this, stated with the estimate: 90%; the middle value does not contradict the limit.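

In this assay compound 3 gives > 50000 nM, a limit. Compound 4 gives > 100000 nM, also a limit, so no step can be read between compound 3 and compound 4. The compounds shown leave open what size of step hydroxycarbamoyl to carboxy makes on either core.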